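This account rests on a few compounds, and the source may have more. Where it says the series, first, only, none or still open, it means among the compounds named here.

Measured in a functional assay on MCF7 cells (Homo sapiens) for inhibition, read by sulforhodamine B assay; on this read-out lower numbers stand for stronger inhibition of growth and higher numbers for weaker inhibition of growth:
- Compound 1 `FC(F)(F)Oc1ccc(-c2ccc(-c3ccc(-c4nc5ccccc5[nH]4)cc3)cc2)cc1`: 38400 nM
- Compound 2 `CN(C)c1ccc(-c2ccc(-c3ccc(-c4nc5ccccc5[nH]4)cc3)cc2)cc1`: 41200 nM
- Compound 3 `COc1ccc(-c2ccc(-c3ccc(-c4nc5ccccc5[nH]4)cc3)cc2)cc1OC`: 7600 nM

Compound 2, at 41200 nM, stands at the top of these three values, but not alone: a 1.1-fold higher number from compound 1 to compound 2 (0.03 log units; within the scatter). The one clear gap is a 5.4-fold lower number from compound 2 to compound 3 (0.73 log units; beyond the scatter).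

The next compound to be tested is compound 4 `CN(C)c1ccc(-c2ccc(-c3ccc(-c4nc5c(O)cccc5[nH]4)cc3)cc2)cc1`. It keeps everything in compound 2 except for one change: hydroxy in place of hydrogen on an aromatic carbon. In words, this is hydroxy in place of hydrogen on an aromatic carbon, turning 1H-benzimidazol-2-yl into 4-hydroxy-1H-benzimidazol-2-yl.

Going by the values given here, no measured step makes this change, and both measured steps alter a different part of the molecule. They can therefore only suggest a likely scale. One exchange left this assay within the scatter, and the other gave a modest shift. Compound 3 also shows that this series can reach 7600 nM, so a small move to a lower number seems somewhat more likely than a move upward, although the data do not settle the direction.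

The expected change is a 2.1-fold lower number from compound 2 to compound 4 (0.31 log units; beyond the scatter), a small step at most modest in size. For compound 4 the estimated value is 20000 nM, with an expected range from 6000 nM to 60000 nM.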

Compound 4, concentration for 50% growth inhibition: 2310 nM
Beside the measured number, compound 4's estimate is 8.7-fold (0.94 log units) above it; the measured number lies below the stated range.
By their numbers in this assay, from the lowest: compound 4; then compound 3; then compounds 1 and 2 (each within the scatter of the next).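

In this assay, the two earlier steps both left the 1H-benzimidazol-2-yl group untouched, so they said nothing about this part of the molecule. Placing a hydroxy on the six-membered aromatic ring of that fused system gives an 18-fold lower number from compound 2 to compound 4 (1.25 log units; beyond the scatter), a large step that exceeds the modest 5.4-fold lower number from compound 2 to compound 3 (0.73 log units; beyond the scatter) and shows that this single added group can shift the growth-inhibition value more than either exchange already seen. Nothing in the information at hand accounts for the size of this shift.

From the compounds shown here alone, the result rests on one pair, so it remains open whether a methoxy group, an amine or a fluorine on the same carbon would give a similar step, and therefore whether the shift is specific to hydroxy. Going by these compounds, it is also open whether the 4-hydroxy-1H-benzimidazol-2-yl group would give a step of similar size when paired with the trifluoromethoxy group of compound 1 or the 3,4-dimethoxyphenyl group of compound 3, rather than with the dimethylamino group of compound 2.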